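The source may hold more compounds than are shown below. What is called first, only, known or untested is meant among the compounds shown, and "the series" means these compounds.

Among the measured compounds shown here, compound 1, with the structure `Cc1cc(C(=O)Nc2ccccc2)nn1Cc1cc(Cl)ccc1OCc1ccccc1`, is one of two compounds measured in an assay on CHO-K1 cells for displacement of a labelled ligand from prostaglandin E2 receptor EP1 subtype (Homo sapiens) (a lower number here means a stronger inhibitor, a higher number a weaker inhibitor), where compound 1 gives 39.8 nM. Its companion, compound 2 `Cc1cc(C(=O)NCc2cccnc2)nn1Cc1cc(Cl)ccc1OCc1ccccc1`, carries a (pyridin-3-yl)methyl group in place of the phenyl on the amide-type nitrogen, and in this assay compound 2 gives 50.1 nM. The step of a 1.3-fold higher number from compound 1 to compound 2 (0.10 log units; within the scatter) is within the scatter, so the two numbers cannot be told apart, and compound 1 cannot be called either the stronger or the weaker of the pair.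

Compound 3 `Cc1cc(C(=O)NCc2ccncc2)nn1Cc1cc(Cl)ccc1OCc1ccccc1` has not yet been measured. It differs from compound 1 in one place: (pyridin-4-yl)methyl in place of phenyl on an amide-type nitrogen. For the measured compounds named here, the only measured step that bears on this change is the one from compound 1 to compound 2, where a (pyridin-3-yl)methyl group replaced the same phenyl and the number barely moved. Because that step was a 1.3-fold higher number from compound 1 to compound 2 (0.10 log units; within the scatter), a similar outcome is expected here. The step of a 1.4-fold higher number from compound 1 to compound 3 (0.14 log units; within the scatter) is expected to stay within the scatter. Compound 3 is therefore estimated to give 55 nM in this assay, with a range from 25 nM to 125 nM.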

Compound 3, half-maximal inhibitory concentration: 79.4 nM
For compound 3 the middle estimate is 1.4-fold (0.16 log units) below the measured one; low and high end bracket the measured number.
By their numbers in this assay, from the lowest: compounds 1, 2 and 3 (each within the scatter of the next).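

In this assay, the change of pyridin-4-yl for pyridin-3-yl on the saturated chain carbon gives a 1.6-fold higher number from compound 2 to compound 3 (0.20 log units; within the scatter) and so the two pyridine isomers cannot be told apart by their numbers. The replacement of phenyl by (pyridin-4-yl)methyl on the amide-type nitrogen gives a 2.0-fold higher number from compound 1 to compound 3 (0.30 log units; within the scatter) and this makes it the second replacement at this position to stay inside the scatter, so phenyl, (pyridin-3-yl)methyl and (pyridin-4-yl)methyl show no readable difference here. No separate measurement is available to explain these numbers.

Both steps away from compound 1 add a chain carbon and a ring nitrogen at once, so a plain benzyl group on the same nitrogen would be needed to separate the two changes. As far as these compounds go, it also remains open whether this position stays as undemanding with a (pyridin-2-yl)methyl group, a longer chain ending in a phenyl ring, or a group of a different kind such as a carboxylic acid or an amine.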